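A few compounds are considered here, and "the series" means these few. Any claim that something is new, unique, unknown or untested is made for them only; others in the source may bear on it.

For the measured compounds named here, compound 3 `CN1CCC(NC(=O)c2ccncc2Nc2cc(-c3ccc4ccn(C)c4c3)c3nccnc3c2)CC1` is one of three compounds measured in an assay for inhibition of 6-phosphofructo-2-kinase/fructose-2,6-bisphosphatase 3 (Homo sapiens), read by ADP-Glo, with a stated time of 2 h; a lower number here means a stronger inhibitor, a higher number a weaker inhibitor. Compound 1 `CN1CCC(CNS(=O)(=O)c2ccccc2Nc2cc(-c3ccc4ccn(C)c4c3)c3nccnc3c2)C1` gives 11 nM, compound 2 `Cn1ccc2ccc(-c3cc(Nc4ccccc4S(=O)(=O)NCC4CCOCC4)cc4nccnc34)cc21` gives 26 nM, and compound 3 gives 38 nM, the highest of the three numbers. Compound 3 and compound 2 lie within the scatter of each other, while compound 1 sits a clear step lower than compound 3.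

Compound 4 `CC(=O)N1CC(CNC(=O)c2ccncc2Nc2cc(-c3ccc4ccn(C)c4c3)c3nccnc3c2)C1` differs from compound 3 in one place: (1-acetylazetidin-3-yl)methyl in place of 1-methylpiperidin-4-yl on an amide-type nitrogen. Among the measured pairs, only the step from compound 1 to compound 2 alters the saturated ring at the end of the side chain, and there it produced a 2.4-fold higher number from compound 1 to compound 2 (0.37 log units; beyond the scatter). Going by the values given here, that step is the only guide for the change from compound 3 to compound 4, and it was modest. The ring that leaves compound 3 and the group that enters are not the same pair as in that step, so the comparison is loose. A modest rise beyond the scatter is nonetheless expected, giving an estimated step of a 2.1-fold higher number from compound 3 to compound 4 (0.32 log units; beyond the scatter) in this assay. Compound 4 is therefore estimated at 80 nM, within a range from 30 nM to 220 nM.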

Compound 4, half-maximal inhibitory concentration: 137 nM
Beside the measured number, compound 4's estimate is 1.7-fold (0.23 log units) below it; the measured number falls inside the stated range.
By their numbers in this assay, from the lowest: compound 1; then compounds 2 and 3 (each within the scatter of the next); then compound 4.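

In this assay, the replacement on the amide-type nitrogen gives a 3.6-fold higher number from compound 3 to compound 4 (0.56 log units; beyond the scatter), showing that the group at the end of the side chain also affects the number on this amide-type attachment, whereas the earlier step concerned a sulfonamide nitrogen. The rise comes with a four-membered ring in place of a six-membered one and an added double bond outside aromatic rings, while the counts of hydrogen-bond donors and acceptors remain the same, so those counts alone do not track the step in this pair. Nothing available here accounts for the rise in compound 4.

Going by these compounds, this single change alters the ring size, the substituent on the ring nitrogen and the link to the amide-type nitrogen together, so the share of each in the step remains open. A 1-acetylpiperidin-4-yl group on the amide-type nitrogen would keep the six-membered ring of compound 3 while carrying the acetyl of compound 4, and a (1-methylazetidin-3-yl)methyl group would keep the ring and link of compound 4 with a methyl on the ring nitrogen.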